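The source may hold more compounds than are shown below. What is called first, only, known or untested is meant among the compounds shown, and "the series" means these compounds.

Working notes on the series. In an ADME assay on a cell-free system (plasma, Mus musculus, strain C57BL/6) for metabolic stability, read by HPLC, with a stated time of 12 h (a higher number here means that the compound lasts longer, a lower number that the compound disappears faster), compound 2 `O=C(O)[C@@H](CO)NC(=O)[C@H]1C[C@@H](O)CN1` reads > 12 h, which is a limit of the assay and not a number. Compound 1 `O=C(O)[C@H](CO)NC(=O)[C@H]1C[C@H](O)CN1` reads > 12 h, also a limit. Both compounds therefore sit at the limit of > 12 h in this assay, at which 2 of the 2 values shown sit, and compound 2 has no exact position in the series.

The next structure is compound 3 `O=C(O)[C@@H](CO)NC(=O)[C@H]1C[C@H](O)CN1`, and the change is this: the two compounds have the same atoms and bonds and differ only in configuration as drawn: 1 of 3 stereo elements differ; a stereocentre at a saturated ring carbon is drawn R in compound 2 and S in compound 3.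

For the measured compounds named here, the one measured step bearing on this is a step that the two limits leave unreadable from compound 1 to compound 2, which also involves a stereocentre at a saturated ring carbon, alongside one at a saturated chain carbon. It rests on (the fact that compounds 1 and 2 differ only in the configuration as drawn), and it gives no size to carry over. The expectation in this assay is therefore a step that the limit leaves unreadable from compound 2 to compound 3, with no direction and nothing beyond the usual scatter.

For compound 3 the estimate is 15 h, with an expected range of 12 h to 30 h, and a further limit is the likeliest report.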

Compound 3, half-life: > 12 h
Compound 3: no number, only a limit; the forecaster's own chance of this, stated with the estimate: 85%; the middle value lies beyond the limit too.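

Compound 3 adds no readable step to compound 1 or compound 2 in this assay, since all three compounds stand at one limit of the assay, not at a number: the limit of > 12 h in this assay, at which 3 of the 3 values shown sit.

The compounds shown leave open how long each compound actually lasts and whether the drawn configuration alters this at all.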